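The source may report more compounds than this note shows. Statements on the series, on what has been measured and on what is new or still open speak of the compounds shown alone.

Compound 1 `O=C(c1ccc(F)cc1)c1ccn(-c2ccc3c(c2)B(O)OC3)c1`: in an ADME assay on L929 cells (Mus musculus) for cytotoxicity, read by resazurin assay, with a stated time of 72 h (on this read-out higher numbers stand for weaker inhibition and lower numbers for stronger inhibition), compound 1 gives > 10 ug/mL, which is a limit of the assay rather than a number.
Compound 2 `COc1ccccc1C(=O)c1ccn(-c2ccc3c(c2)B(O)OC3)c1`: compound 2 gives > 10 ug/mL, again a limit.
Compound 3 `O=C(c1ccc(CO)cc1)c1ccn(-c2ccc3c(c2)B(O)OC3)c1`: compound 3 gives 9.31 ug/mL.

Compound 3 is therefore the only one of the three with an actual number; the other two values sit at the limit of > 10 ug/mL in this assay, at which 2 of the 3 values shown sit. Compound 4 `O=C(CCc1ccccc1)c1ccn(-c2ccc3c(c2)B(O)OC3)c1` has not been measured. It differs from compound 3 by phenethyl in place of 4-(hydroxymethyl)phenyl on a carbonyl carbon. The measured steps that bear on this are an at least 1.0-fold lower number from compound 1 to compound 3 (0.03 log units; that floor lies within the scatter) and an at least 1.0-fold lower number from compound 2 to compound 3 (0.03 log units; that floor lies within the scatter), each readable only as a floor that lies within the scatter, while a step that the two limits leave unreadable from compound 1 to compound 2. Nothing in these three compounds points to a step beyond the scatter, so the expected step of a 1.3-fold higher number from compound 3 to compound 4 (0.11 log units; within the scatter) is small. Compound 4 is estimated at 12 ug/mL, between 5 ug/mL and 30 ug/mL, with a real chance that only a limit is reported.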

Compound 4, half-maximal inhibitory concentration: > 10 ug/mL
Compound 4: only a limit was reported; the forecaster's own chance of this, stated with the estimate: 60%; the middle value lies beyond the limit too.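

On this carbonyl carbon, phenethyl replaces 4-(hydroxymethyl)phenyl, giving 0 hydrogen-bond donors and 0 hydrogen-bond acceptors in place of 1 of each. In this assay, on these data alone, this gives an at least 1.0-fold higher number from compound 3 to compound 4 (0.03 log units; that floor lies within the scatter), so the true size of the step stays unknown. The steps to compound 4 from compound 1 and compound 2 cannot be read, and the set now rests mostly on one limit of the assay: the limit of > 10 ug/mL in this assay, at which 3 of the 4 values shown sit.

As far as these compounds go, how far the limit compounds lie past that limit remains open. So does whether an amine or a carboxylic acid on the aromatic ring would give a step beyond the scatter.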